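Swapping the benzyl group of compound 2

This account rests on a few compounds, and the source may have more. Where it says the series, first, only, none or still open, it means among the compounds named here.

In a functional assay on HUVEC cells (Homo sapiens) for antiproliferative activity, read by MTT assay, with a stated time of 24 h (a lower number here means a stronger inhibitor, a higher number a weaker inhibitor), compound 2 `COc1cc(OC)c(-c2coc3cc(OCc4ccccc4C)ccc3c2=O)cc1OC` gives 4830 nM. This is the only full number shown; the one other value recorded is a limit rather than a number. Compound 1 `COc1cccc(C(=O)Oc2ccc3c(=O)c(-c4cc(OC)c(OC)cc4OC)coc3c2)c1` reaches only the limit of > 10000 nM in this assay. That limit is the limit of > 10000 nM in this assay, at which 1 of the 2 values shown sits. The measured step of an at least 2.0-fold lower number from compound 1 to compound 2 (0.31 log units; beyond the scatter) shows that the 2-methylbenzyl ether is more potent than the ester, but it does not compare two different benzyl groups with one another. Compound 3 `COc1cc(OC)c(-c2coc3cc(OCc4ccc(C(F)(F)F)cc4)ccc3c2=O)cc1OC` differs from compound 2 by 4-(trifluoromethyl)phenyl in place of 2-methylphenyl on a saturated chain carbon bound to an oxygen on an aromatic ring. Among the measured compounds shown here, no measured step follows such a swap on this core, so nothing in the data points to a change beyond the scatter in this assay. Compound 3 is therefore expected to give about 4800 nM in this assay, between 1500 nM and 15000 nM. The step of a 1.0-fold lower number from compound 2 to compound 3 (0.00 log units; within the scatter) that this estimate means is expected to stay within the scatter.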

Compound 3, half-maximal inhibitory concentration: > 10000 nM
Compound 3: a limit, no number; the forecaster's own chance of this, stated with the estimate: 25%; middle value at least 2.0-fold (0.31 log units) away from the limit.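

Among the compounds shown here, this is the first sign that the aromatic group on the saturated chain carbon matters, and not only the change from ester to ether: in this assay, 4-(trifluoromethyl)phenyl in place of 2-methylphenyl gives an at least 2.0-fold higher number from compound 2 to compound 3 (0.31 log units; beyond the scatter). The value of compound 3 is a limit and not a number, so this step gives only a minimum size, and the step between compound 1 and compound 3 cannot be read, as both values are limits. Compound 2 remains the only compound with a full number: the limit of > 10000 nM in this assay, at which 2 of the 3 values shown sit.

The compounds shown leave open whether the step comes from losing the 2-methyl group, from gaining the trifluoromethyl group, or from the different place of the group on the ring. Neither a plain benzyl nor a 4-methylbenzyl group is among them to separate these readings.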